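Benzylselanyl for methylsulfanyl on an acylated amidine scaffold

This account rests on a few compounds, and the source may have more. Where it says the series, first, only, none or still open, it means among the compounds named here.

Of the compounds shown here, three have been measured in an ADME assay on MCF-10A cells (Homo sapiens) for cytotoxicity, read by MTT assay, with a stated time of 72 h; on this read-out higher numbers stand for weaker inhibition of growth and lower numbers for stronger inhibition of growth. Compound 3 `CS/C(=N\C(=O)c1cc(-c2ccccc2)nc2ccccc12)NC(=O)c1cc(-c2ccccc2)nc2ccccc12` gives 540 nM. Compound 2 `O=C(/N=C(/NC(=O)c1cc(-c2ccccc2)nc2ccccc12)[Se]Cc1ccccc1)c1cc(-c2ccccc2)nc2ccccc12` carries a group of 8 heavy atoms (7 carbon, 1 selenium; one six-membered aromatic ring of carbon only) in place of a group of 2 heavy atoms (1 carbon, 1 sulfur; no ring), on a carbon with a double bond to nitrogen and gives 45600 nM; the step of an 84-fold higher number from compound 3 to compound 2 (1.93 log units; beyond the scatter). Compound 1 `CS/C(=N\C(=O)c1csc([N+](=O)[O-])c1)NC(=O)c1csc([N+](=O)[O-])c1` has a core that differs from the core of compound 3 in a way not broken down here; in this assay compound 1 gives 21400 nM. Compound 4 `O=C(/N=C(/NC(=O)c1csc([N+](=O)[O-])c1)[Se]Cc1ccccc1)c1csc([N+](=O)[O-])c1` is not yet measured; it bears a group of 8 heavy atoms (7 carbon, 1 selenium; one six-membered aromatic ring of carbon only) in place of a group of 2 heavy atoms (1 carbon, 1 sulfur; no ring), on a carbon with a double bond to nitrogen, the same change at the same place as between compound 3 and compound 2. The step for compound 4 is expected to be a 9.3-fold higher number from compound 1 to compound 4 (0.97 log units; beyond the scatter), smaller than the earlier one because compound 1 already gives 21400 nM, a weaker starting point; the core also differs. Compound 4 is estimated at 200000 nM, between 50000 nM and 2000000 nM.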

Compound 4, concentration for total growth inhibition: 54100 nM
Compound 4: the middle estimate sits 3.7-fold (0.57 log units) above what was measured; the range from low to high includes it.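

In this assay the change from methylsulfanyl to benzylselanyl, on a carbon with a double bond to nitrogen, gives a 2.5-fold higher number from compound 1 to compound 4 (0.40 log units; beyond the scatter). The direction carries over to the core of compound 1, but the size of the step does not: the same change on two cores in this assay, an 84-fold higher number (1.93 log units; beyond the scatter) from compound 3 to compound 2 and a 2.5-fold higher number (0.40 log units; beyond the scatter) from compound 1 to compound 4, 33-fold (1.52 log units) apart, beyond the scatter of two such steps.
Two cores do not show which feature of the core sets the size of the step, or whether the direction holds on any further core.

The compounds shown change selenium and the benzyl part together, so the share of each in the step stays open. Methylselanyl or benzylsulfanyl on the same carbon would separate the two, and an amine there would test a different kind of group.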